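The source may report more compounds than this note shows. Statements on the series, on what has been measured and on what is new or still open speak of the compounds shown alone.

Measured in an in vitro ADME assay on microsomes from liver (Homo sapiens) for pharmacokinetics; on this read-out higher numbers stand for fast clearance and lower numbers for slow clearance:
- compound 1 `COC(=O)c1ccc(C(=O)N2C[C@H]3CN(CC[C@H](NC(C)=O)c4ccccc4)C[C@H]3C2)cc1`: 77 mL.min-1.g-1
- compound 2 `O=C(N[C@@H](CCN1C[C@@H]2CN(C(=O)c3ccccn3)C[C@@H]2C1)c1cccc(F)c1)C1CCCC1`: 512 mL.min-1.g-1
- compound 3 `O=C(N[C@@H](CCN1C[C@@H]2CN(C(=O)c3cncnc3)C[C@@H]2C1)c1cccc(F)c1)C1CCCC1`: 332 mL.min-1.g-1

Among these three numbers, compound 3 lies within the usual scatter of compound 2, and compound 1 is clearly lower than both. Compound 4 `O=C(N[C@@H](CCN1C[C@@H]2CN(C(=O)c3cnccn3)C[C@@H]2C1)c1cccc(F)c1)C1CCCC1` keeps everything in compound 3 except one ring: pyrazin-2-yl in place of pyrimidin-5-yl on a carbonyl carbon. This puts pyrazin-2-yl in place of pyrimidin-5-yl on a carbonyl carbon. Within the data shown here, only one measured step bears on this place: a 1.5-fold lower number from compound 2 to compound 3 (0.19 log units; within the scatter), which exchanged pyridin-2-yl for pyrimidin-5-yl. That single step suggests that such ring exchanges move this assay little, so no change beyond the scatter is expected. The estimated step is a 1.1-fold higher number from compound 3 to compound 4 (0.06 log units; within the scatter). Compound 4 is expected at about 380 mL.min-1.g-1, with an estimated range from 200 mL.min-1.g-1 to 650 mL.min-1.g-1.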

Compound 4, intrinsic clearance in microsomes: 909 mL.min-1.g-1
Estimate against measurement, compound 4: 2.4-fold (0.38 log units) below; measured number above the stated range.
By their numbers in this assay, from the lowest: compound 1; then compounds 3, 2 and 4 (each within the scatter of the next, the first and the last beyond it).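

Swapping pyrimidin-5-yl for pyrazin-2-yl on a carbonyl carbon gives a 2.7-fold higher number from compound 3 to compound 4 (0.44 log units; beyond the scatter) in this assay, so at this place the same ring atoms joined differently are enough to separate two compounds beyond the scatter. Pyrazin-2-yl in place of pyridin-2-yl gives a 1.8-fold higher number from compound 2 to compound 4 (0.25 log units; within the scatter), so not every ring exchange here is as large. No supporting data explain the difference between these rings. Still open, going by these compounds, is how a pyrazin-2-yl ring carrying an amine or a carboxylic acid would read in this assay, and whether the ring exchange behaves the same on the core of compound 1.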